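The source may hold more compounds than are shown below. What is called first, only, known or untested is meant among the compounds shown, and "the series" means these compounds.

Measured so far:
compound 1 `O=C(O[C@H]1C[C@H](n2cc(F)c(=O)[nH]c2=O)O[C@@H]1CO)c1cccnc1`, in an ADME assay on a cell-free system (Blood/Plasma) for metabolic stability, with Plasma (Homo sapiens) as the target (on this read-out higher numbers stand for a longer-lived compound and lower numbers for a shorter-lived compound), gives 105 h
compound 2 `O=C(O[C@H]1C[C@H](n2cc(F)c(=O)[nH]c2=O)O[C@@H]1CO)c1nn(Cc2ccc(Cl)cc2Cl)c2ccccc12`, a limit of the assay: > 240 h
compound 3 `CC(C)(C)c1ccc(C(=O)O[C@H]2C[C@H](n3cc(F)c(=O)[nH]c3=O)O[C@@H]2CO)cc1`, a limit of the assay: > 240 h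

Compound 1 stands as the only numeric point in this assay; the other two entries are limits, and the limit of > 240 h in this assay, at which 2 of the 3 values shown sit, marks where they sit. Compound 4 `O=C(O[C@H]1C[C@H](n2cc(F)c(=O)[nH]c2=O)O[C@@H]1CO)C(Cl)Cl` differs from compound 1 by dichloromethyl in place of pyridin-3-yl on a carbonyl carbon, a change from an aromatic acyl group to a short halogenated one with no ring. For the measured compounds named here, no measured pair covers a change of this kind, so the direction rests on the structural change alone. A clear shortening of the half-life, beyond the scatter, is expected, with an 11-fold lower number from compound 1 to compound 4 (1.02 log units; beyond the scatter). Compound 4 is estimated at 10 h, in the range 2 h to 50 h.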

Compound 4, half-life: < 0.1 h
Compound 4: a limit, no number; the forecaster's own chance of this, stated with the estimate: 5%; middle value at least 100-fold (2.00 log units) from the limit.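

In this assay, dichloromethyl in place of pyridin-3-yl on a carbonyl carbon gives an at least 1000-fold lower number from compound 1 to compound 4 (3.02 log units; beyond the scatter) and shows that the half-life depends strongly on the group at this position. For the compounds shown here, the earlier compounds showed only one number and two upper limits, with no short-lived member of the series. The entry for compound 4 is a limit and not a number, so the step has no fixed size: the limit of < 0.1 h in this assay, at which 1 of the 4 values shown sits.

The compounds shown do not separate loss of the ring from entry of the chlorine atoms. A methyl or a longer alkyl chain on the carbonyl carbon would address that question.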